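Swapping the halogen on the amide-side phenyl ring

This account rests on a few compounds, and the source may have more. Where it says the series, first, only, none or still open, it means among the compounds named here.

Measured in a functional assay on NCI-H1975 cells (Homo sapiens) for inhibition, read by MTT assay, with a stated time of 72 h; on this read-out higher numbers stand for weaker inhibition and lower numbers for stronger inhibition:
compound 1, `O=C(CSc1nc(Nc2ccccc2)c2ccccc2n1)Nc1cccc([N+](=O)[O-])c1`, 17900 nM
compound 2, `O=C(CSc1nc(Nc2ccccc2)c2ccccc2n1)Nc1ccc(Cl)cc1`, 8040 nM

Compound 2 gives the lower of the two numbers; compound 1 sits higher by a 2.2-fold lower number from compound 1 to compound 2 (0.35 log units; beyond the scatter). Compound 3, `O=C(CSc1nc(Nc2ccccc2)c2ccccc2n1)Nc1ccc(Br)cc1`, differs from compound 2 only by bromo in place of chloro on an aromatic carbon. Among the compounds with values here, no measured step involves this exchange; the only measured step swapped two different groups, so it gives no direct guide. The change is small in what it counts, so the step from compound 2 to compound 3 is expected to stay within the scatter, estimated as a 1.2-fold lower number from compound 2 to compound 3 (0.09 log units; within the scatter). Compound 3 is therefore estimated at 6500 nM, with a range from 3000 nM to 15000 nM.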

Compound 3, half-maximal inhibitory concentration: 10600 nM
Compound 3: the middle estimate sits 1.6-fold (0.21 log units) below what was measured; measured number inside the range.
By their numbers in this assay, from the lowest: compounds 2, 3 and 1 (each within the scatter of the next, the first and the last beyond it).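

In this assay, the step from chloro to bromo on this ring carbon is a 1.3-fold higher number from compound 2 to compound 3 (0.12 log units; within the scatter), so the two halogens cannot be told apart here. Replacing 3-nitrophenyl with 4-bromophenyl gives a 1.7-fold lower number from compound 1 to compound 3 (0.23 log units; within the scatter), so compound 3 cannot be separated from compound 1, although compound 2 can. Nothing measured here offers an explanation for either result.

Going by these compounds, whether a fluoro group, an amine or a carboxylic acid at the same carbon would give a clearly different number remains open. So does whether any change to this ring could strengthen inhibition well beyond these values.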